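Aryl variation on the alkyne of a shared core

The source may report more compounds than this note shows. Statements on the series, on what has been measured and on what is new or still open speak of the compounds shown alone.

Three compounds share one core and differ only in the aryl group on the triple-bonded carbon. In an assay on CHO cells for displacement of a labelled ligand from adenosine receptor A1 (Homo sapiens), read by scintillation counting, with a stated time of 60 min, tested at 10 uM (on this read-out lower numbers stand for less inhibition and higher numbers for more inhibition at the one concentration tested (going by the name of the read-out)), compound 1 `CNC(=O)[C@@]12C[C@@H]1[C@@H](n1cnc3c(NC)nc(C#Cc4cccc(F)c4)nc31)[C@H](O)[C@@H]2O` gives 14%, compound 2 `CNC(=O)[C@@]12C[C@@H]1[C@@H](n1cnc3c(NC)nc(C#Cc4ccccc4OC)nc31)[C@H](O)[C@@H]2O` gives 12%, and compound 3 `CNC(=O)[C@@]12C[C@@H]1[C@@H](n1cnc3c(NC)nc(C#Cc4ccc(CO)cc4)nc31)[C@H](O)[C@@H]2O` gives 16%. The number for compound 2 is the lowest of the three, but the steps of a number 2 percentage points lower from compound 1 to compound 2 (within the scatter) and a number 4 percentage points higher from compound 2 to compound 3 (within the scatter) are both within the scatter, as is a number 2 percentage points higher from compound 1 to compound 3 (within the scatter), so the three aryl groups cannot be told apart on this read-out.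

Compound 4 `CNC(=O)[C@@]12C[C@@H]1[C@@H](n1cnc3c(NC)nc(C#Cc4cc5ccccc5o4)nc31)[C@H](O)[C@@H]2O` is not yet measured. It differs from compound 2 by 1-benzofuran-2-yl in place of 2-methoxyphenyl on a triple-bonded carbon. Among the compounds with values here, no measured step involves a 1-benzofuran-2-yl group, so the nearest guide is the set of aryl exchanges already seen, each of which moved the read-out in this assay by an amount within the scatter. The step from compound 2 to compound 4 is therefore expected to be a number 2 percentage points higher from compound 2 to compound 4 (within the scatter), with no change beyond the scatter anticipated. Compound 4 is estimated to give 14% in this assay, within a range from 3% to 28%.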

Compound 4, a percentage reported as inhibition, at one concentration (the size of the read-out at that concentration, not a potency): 13%
Estimate against measurement, compound 4: 1 percentage points above, within the range that was stated.
By their numbers in this assay, from the lowest: compounds 2, 4, 1 and 3 (each within the scatter of the next).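

Within the data shown here, the triple-bonded carbon now also carries a group with a five-membered aromatic ring alongside a six-membered one, whereas the earlier compounds carried a single six-membered aromatic ring. In this assay this larger change still gives no step beyond the scatter (a number 1 percentage points higher from compound 2 to compound 4 (within the scatter)) and (a number 1 percentage points lower from compound 1 to compound 4 (within the scatter)) and (a number 3 percentage points lower from compound 3 to compound 4 (within the scatter)). The four aryl groups therefore cannot be ordered on this read-out, and the ring oxygen of 1-benzofuran-2-yl gives no separation from the other three. No supporting data bear on this result.

On these data alone, it remains open whether an aminomethyl group, a carboxylic acid or a longer alkyl chain on the aryl ring would move the read-out beyond the scatter. A single-concentration percentage also leaves the potency of these compounds undefined.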